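Adding a (propanoyloxy)methyl Group to Compound 1

A few compounds are considered here, and "the series" means these few. Any claim that something is new, unique, unknown or untested is made for them only; others in the source may bear on it.

Compound 1 `Nc1ccc(-c2cc(=O)c3c(N)c(F)cc(F)c3o2)cc1F` was tested in a functional assay on HeLa cells (Homo sapiens) for cytotoxicity, read by neutral red uptake, with a stated time of 3 days; a higher number here means a weaker inhibitor, a lower number a stronger inhibitor. Compound 1 gives > 100000 nM, which is a limit of the assay rather than a number. Two relatives were also measured. Compound 2 `Nc1ccc(-c2cc(=O)c3c(N)c(F)c(Br)c(F)c3o2)cc1F`, carrying bromo in place of hydrogen on an aromatic carbon, gives > 100000 nM, again a limit. Compound 3 `Nc1ccc(-c2cc(=O)c3c(N)c(F)c(C(=O)O)c(F)c3o2)cc1F`, carrying carboxy in place of hydrogen on an aromatic carbon, gives > 100000 nM, also a limit. Because all three values sit at the limit of > 100000 nM in this assay, at which 3 of the 3 values shown sit, none of the steps among them can be read: a step that the two limits leave unreadable from compound 1 to compound 2, a step that the two limits leave unreadable from compound 1 to compound 3 and a step that the two limits leave unreadable from compound 2 to compound 3 are all of unknown size.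

Compound 4 `CCC(=O)OCc1c(F)c(N)c2c(=O)cc(-c3ccc(N)c(F)c3)oc2c1F` differs from compound 1 by (propanoyloxy)methyl in place of hydrogen on an aromatic carbon. The two measured steps from compound 1 bear on this change, since each also exchanges hydrogen on an aromatic carbon for a new group, yet neither gives a readable size. Nothing in this series therefore points to a movement in this assay beyond the scatter in either direction, and a limit is the most likely outcome once more. Compound 4 is expected to give 150000 nM, with a range from 50000 nM to 500000 nM. The step that the limit leaves unreadable from compound 1 to compound 4 is thus estimated to be small or not measurable.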

Compound 4, half-maximal inhibitory concentration: 69000 nM
Compound 4: the middle estimate sits 2.2-fold (0.34 log units) above what was measured; the range from low to high includes it.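

At this position, the aromatic carbon ortho to two fluoro groups, (propanoyloxy)methyl gives the first readable number in this assay, while the other three compounds all stop at a limit: the limit of > 100000 nM in this assay, at which 3 of the 4 values shown sit.

Measured against hydrogen, the change is an at least 1.4-fold lower number from compound 1 to compound 4 (0.16 log units; that floor lies within the scatter), and the exchanges for carboxy and bromo at the same carbon read an at least 1.4-fold lower number from compound 3 to compound 4 (0.16 log units; that floor lies within the scatter) and an at least 1.4-fold lower number from compound 2 to compound 4 (0.16 log units; that floor lies within the scatter). Each of these steps is only a floor, so the true gaps may be larger, but as printed they cannot be told from the scatter, and the series shows only that this position can carry a group with a measurable value, not that the group clearly lowers the number.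

The compounds shown leave open how far the true values of compound 1, compound 2 and compound 3 lie from compound 4, so the real size of all three steps stays unknown. They also leave open which part of the new group goes with the readable value, a question that a hydroxymethyl group, an aminomethyl group or a longer chain such as (butanoyloxy)methyl at the same carbon would address.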